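Pyridin-2-yl amide in place of the thiazolyl amide

The compounds below may be only part of what the source reports. "The series", "measured", "known", "first", "only" and "open" are said of these compounds alone.

Three compounds share a common core and differ in the group carried on the amide. Compound 1 `Cc1c(NC(=O)COc2ccc(/C=C3\SC(=O)NC3=O)cc2)c(=O)n(-c2ccccc2)n1C` was tested in a functional assay on HOP-62 cells (Homo sapiens) for cytotoxicity, read by sulforhodamine B assay, with a stated time of 48 h; on this read-out higher numbers stand for weaker inhibition of growth and lower numbers for stronger inhibition of growth. In this assay compound 1 gives < 100000 nM, which is a limit of the assay rather than a number. Compound 2 `Cc1cnc(NC(=O)COc2ccc(/C=C3\SC(=O)NC3=O)cc2)s1` gives < 100000 nM in this assay, again a limit. Compound 3 `O=C1NC(=O)/C(=C\c2ccc(OCC(=O)N3C(=O)c4ccccc4S3(=O)=O)cc2)S1` gives < 100000 nM in this assay, also a limit. All three therefore sit at the limit of < 100000 nM in this assay, at which 3 of the 3 values shown sit, so compound 2 cannot be placed against either of the others on the numbers shown; nothing separates them.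

Compound 4 `O=C(COc1ccc(/C=C2\SC(=O)NC2=O)cc1)Nc1ccccn1` has not yet been measured in this assay. It is reached from compound 2 by pyridin-2-yl in place of 5-methyl-1,3-thiazol-2-yl on an amide-type nitrogen. Among the measured compounds shown here, no step between measured compounds is available to gauge this change, and since every value so far is a limit, the expected step that the limit leaves unreadable from compound 2 to compound 4 is taken as none beyond the scatter. Compound 4 is accordingly expected to give 50000 nM in this assay, within an estimated range from 10000 nM to 100000 nM, and most likely to be reported once more as a limit.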

Compound 4, concentration for total growth inhibition: < 100000 nM
Compound 4 was reported as a limit; the forecaster's own chance of this, stated with the estimate: 80%; the middle value does not contradict the limit.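

In this assay compound 4 is reported only as a limit, as is compound 2, so no step can be read from one to the other: the limit of < 100000 nM in this assay, at which 4 of the 4 values shown sit. The compounds shown leave open whether pyridin-2-yl in place of 5-methyl-1,3-thiazol-2-yl on an amide-type nitrogen alters growth inhibition at all, and what actual value any of the four compounds has.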